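Shortening the ketone chain in a glutamate receptor modulator

The source may hold more compounds than are shown below. What is called first, only, known or untested is meant among the compounds shown, and "the series" means these compounds.

Within the data shown here, compound 3 `COc1cc(C(=O)O)ccc1OCCCCOc1ccc(C(=O)CC(C)(C)C)c(O)c1C` reaches the largest maximal response of the three compounds measured so far in an assay on HEK293 cells for positive allosteric modulation of metabotropic glutamate receptor 2 (Rattus norvegicus), read by thallium flux, with a stated time of 2.5 min (a lower number here means a smaller maximal response, a higher number a larger maximal response), giving 98.6%. Compound 1 `COc1cc(C(=O)O)ccc1OCCCCOc1ccc(C(=O)CC(C)C)c(O)c1C` gives 85.7% and compound 2 `CCC(=O)c1ccc(OCCCCOc2ccc(C(=O)O)cc2C)c(C)c1O` gives 86.6%. Compound 4 `CCC(=O)c1ccc(OCCCCOc2ccc(C(=O)O)cc2OC)c(C)c1O` has not yet been measured; it differs from compound 3 by methyl in place of tert-butyl on a saturated chain carbon bound to a carbonyl carbon. Among the measured compounds shown here, one measured step bears on this change: adding a methyl at the same chain position gave a number 12.9 percentage points higher from compound 1 to compound 3 (beyond the scatter). Removing three methyls from that position should run the other way, so a decrease of similar size is expected in this assay, and compound 2, which also carries a propanoyl group, sits in the same region. Compound 4 is therefore expected to give 86%, within 75% to 97%, an estimated step of a number 12.6 percentage points lower from compound 3 to compound 4 (beyond the scatter).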

Compound 4, largest response reached (reported as percent of maximum), in percent of the reference or control that the assay uses: 86.5%
Estimate against measurement, compound 4: 0.5 percentage points below; the range from low to high includes it.
By their numbers in this assay, from the lowest: compounds 1, 4 and 2 (each within the scatter of the next); then compound 3.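

Measured in this assay the change from tert-butyl to methyl on the ketone chain gives a number 12.1 percentage points lower from compound 3 to compound 4 (beyond the scatter) and so confirms that removing bulk here can lower the response. Methyl in place of isopropyl gives a number 0.8 percentage points higher from compound 1 to compound 4 (within the scatter) so among these groups tert-butyl alone stands apart. Methoxy in place of methyl on an aromatic carbon gives a number 0.1 percentage points lower from compound 2 to compound 4 (within the scatter) and leaves this pair indistinguishable.

Nothing available explains why tert-butyl stands apart. Going by these compounds, whether a cyclohexyl group or an amine on this chain would match it remains open.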